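The source may report more compounds than this note shows. Statements on the series, on what has been measured and on what is new or still open speak of the compounds shown alone.

Of the compounds shown here, three built on a shared core have been measured in a functional assay on CHO cells for inhibition of metabotropic glutamate receptor 5 (Rattus norvegicus), read by FLIPR and calcium flux; a higher number here means a weaker inhibitor, a lower number a stronger inhibitor. Compound 1 `Cc1ccc2ccc(-c3cccc(C#N)c3)cc2n1` gives 7.7 nM. Compound 2 `Cc1ccc2ccc(-c3cccc(Cl)c3)cc2n1` gives 14000 nM, and compound 3 `Cc1ccc2ccc(-c3cccc(O)c3)cc2n1` gives 19000 nM. Compound 2 stands second highest of these three numbers: its nearest neighbour is reached by a 1.4-fold higher number from compound 2 to compound 3 (0.13 log units; within the scatter), a gap within the scatter, while its furthest is reached by a 1800-fold higher number from compound 1 to compound 2 (3.26 log units; beyond the scatter), a gap far beyond it.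

Compound 4 `Cc1ccc2ccc(-c3cc(Cl)cc(C#N)c3)cc2n1` differs from compound 2 by cyano in place of hydrogen on an aromatic carbon. Going by the values given here, two measured steps bear on this change, both involving the cyano group: a 1800-fold higher number from compound 1 to compound 2 (3.26 log units; beyond the scatter), where chloro stood in place of cyano, and a 2500-fold higher number from compound 1 to compound 3 (3.39 log units; beyond the scatter), where hydroxy stood in place of cyano. Both were large. Compound 4 keeps the chloro of compound 2 and regains a cyano, so a large step downward in this assay is expected, roughly undoing the loss seen earlier. The expected step is therefore a 700-fold lower number from compound 2 to compound 4 (2.85 log units; beyond the scatter). Compound 4 is estimated to give 20 nM, with a range from 4 nM to 200 nM.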

Compound 4, half-maximal inhibitory concentration: 1.4 nM
Beside the measured number, compound 4's estimate is 14-fold (1.15 log units) above it, and the stated range ends above it.
By their numbers in this assay, from the lowest: compound 4; then compound 1; then compounds 2 and 3 (each within the scatter of the next).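

The cyano group does not depend on the absence of the chloro: on the ring that already carries chloro, it brings a 10000-fold lower number from compound 2 to compound 4 (4.00 log units; beyond the scatter) in this assay. The earlier compounds shown here showed cyano only as a swap against chloro or hydroxy, whereas this step shows it entering in place of hydrogen, meta to a chloro group, with the two groups present together. The chloro, which goes with a weak number in compound 2 when no cyano is present, is no hindrance once cyano is there, since adding it brings a 5.5-fold lower number from compound 1 to compound 4 (0.74 log units; beyond the scatter). Nothing shown here gives a measured reason for either step.

Going by these compounds, whether a fluoro or a methoxy group could take the place of the chloro with the same result remains open. So does whether an amide or a carboxylic acid could stand in for the cyano group.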